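Aryl swap on nitrogen, compound 2 to compound 4

This account rests on a few compounds, and the source may have more. Where it says the series, first, only, none or still open, it means among the compounds named here.

In a functional assay on MDA-MB-231 cells (Homo sapiens) for antiproliferative activity, read by MTT assay, with a stated time of 48 h (on this read-out lower numbers stand for stronger inhibition and higher numbers for weaker inhibition), compound 2 `N#Cc1cccc(Nc2ncnc3cc(NC(=O)/C=C/c4ccccc4)sc23)c1` gives 1040 nM. Compound 3 `COc1ccc(/C=C/C(=O)Nc2cc3c(Nc4cc(Cl)cc(Cl)c4)ncnc3s2)cc1` gives 1970 nM, within the scatter of compound 2. Compound 1 `COc1ccc(/C=C/C(=O)Nc2cc3c(Nc4ccc(Cl)c(Cl)c4)ncnc3s2)cc1` gives 16600 nM, beyond the scatter from both.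

Compound 4 `O=C(/C=C/c1ccccc1)Nc1cc2ncnc(Nc3cc(Cl)cc(Cl)c3)c2s1` differs from compound 2 in one place: 3,5-dichlorophenyl in place of 3-cyanophenyl on a nitrogen on an aromatic ring. This puts 3,5-dichlorophenyl in place of 3-cyanophenyl on a nitrogen on an aromatic ring.

Going by the values given here, no measured pair makes this exchange. The nearest evidence is an 8.4-fold lower number from compound 1 to compound 3 (0.93 log units; beyond the scatter), a step beyond the scatter that ends on the incoming 3,5-dichlorophenyl. That step shows the read-out can respond to a change at this nitrogen, but compounds 1 and 3 differ from compound 2 in their core and their acyl side, so its size may not carry over. Compound 3, which holds the incoming group, sits at 1970 nM, so no large shift is anticipated.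

The expected change is a 1.4-fold higher number from compound 2 to compound 4 (0.16 log units; within the scatter), a slight rise that stays within the scatter. For compound 4 the estimated value is 1500 nM, with an expected range of 500 nM to 4500 nM.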

Compound 4, half-maximal inhibitory concentration: 1000 nM
The estimate for compound 4 lay 1.5-fold (0.18 log units) above the measured number, and the stated range covers the measured number.
By their numbers in this assay, from the lowest: compounds 4, 2 and 3 (each within the scatter of the next); then compound 1.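

Going by these compounds alone, compound 4 gives the first direct exchange at this nitrogen on a shared core, and in this assay the step is small: a 1.0-fold lower number from compound 2 to compound 4 (0.02 log units; within the scatter). Within the data shown here, the 3-cyanophenyl and 3,5-dichlorophenyl groups are therefore not told apart in this pair, so the nitrile is not required for the value seen here, whereas the only earlier step at this nitrogen, an 8.4-fold lower number from compound 1 to compound 3 (0.93 log units; beyond the scatter), lay beyond the scatter and involved two dichlorophenyl groups on a different core. Nothing on hand accounts for this result.

On these data alone, whether the 3,4-dichlorophenyl group would give the same high number on the core of compound 2 stays open, so the earlier step cannot yet be tied to either core. Also open, as far as these compounds go, is how this nitrogen tolerates an aryl group carrying a carboxylic acid or an amine, since both groups compared here are neutral and of equal heavy-atom count.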